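Swapping a Chloro for a Trifluoromethyl Group

The source may report more compounds than this note shows. Statements on the series, on what has been measured and on what is new or still open speak of the compounds shown alone.

Compound 3 `Cc1ccc(S(=O)(=O)N[C@@H](CC(=O)NC(C)(C)C)C(=O)NCCNC(=O)c2ccc(Cl)cc2)cc1` is the starting point. In an ADME assay on HepG2 cells (Homo sapiens) for cytotoxicity (a higher number here means that more compound is needed for the effect, a lower number that less compound is needed), compound 3 reaches only a limit of the assay, > 11000 nM. Compound 1 `Cc1ccc(S(=O)(=O)N[C@@H](CC(=O)NC(C)(C)C)C(=O)NCCNC(=O)c2cc(Cl)ccn2)cc1` likewise stops at a limit, > 11000 nM. Compound 2 `Cc1ccc(S(=O)(=O)N[C@@H](CC(=O)NC(C)(C)C)C(=O)NCCNC(=O)c2cccc(C(C)C)c2)cc1` also returns a limit, > 11000 nM. The three measured steps, a step that the two limits leave unreadable from compound 1 to compound 2, a step that the two limits leave unreadable from compound 1 to compound 3 and a step that the two limits leave unreadable from compound 2 to compound 3, cannot be given a size because of the limit of > 11000 nM in this assay, at which 3 of the 3 values shown sit. Compound 4 `Cc1ccc(S(=O)(=O)N[C@@H](CC(=O)NC(C)(C)C)C(=O)NCCNC(=O)c2cccc(C(F)(F)F)c2)cc1` differs from compound 3 in one place: 3-(trifluoromethyl)phenyl in place of 4-chlorophenyl on a carbonyl carbon. Within the data shown here, no measured step carries a readable size for this change, and none of the three compounds shows any reading short of the limit. Compound 4 is therefore expected to sit at the limit too, with an estimated 15000 nM in a range from 8000 nM to 40000 nM. The expected step is a step that the limit leaves unreadable from compound 3 to compound 4.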

Compound 4, half-maximal effective concentration: > 11000 nM
Compound 4 ended at the assay's limit (the forecaster's own chance of this, stated with the estimate: 85%); the middle value is on the limit's open side.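

No step between compound 4 and compound 1, compound 2 or compound 3 can be read, because all four stop at the same limit: the limit of > 11000 nM in this assay, at which 4 of the 4 values shown sit.

Whether the changes among these compounds alter the concentration needed for an effect in this assay remains open.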